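The source may report more compounds than this note shows. Statements on the series, on what has been measured and on what is new or still open speak of the compounds shown alone.

Of the compounds shown here, two of one shared core have been measured in a functional assay on MCF7 cells (Homo sapiens) for inhibition; on this read-out lower numbers stand for stronger inhibition and higher numbers for weaker inhibition. Compound 1, `CC1=C(SCCCO)C(=O)c2ccccc2C1=O`, gives 5160 nM in this assay. Compound 2, `CC1=C(SCCCCCCO)C(=O)c2ccccc2C1=O`, gives 9280 nM in this assay. Among the compounds with values here, the single step between them, a 1.8-fold higher number from compound 1 to compound 2 (0.25 log units; within the scatter), is a move that stays within the scatter, so the two compounds cannot be ordered against each other. Among the two numbers in hand, compound 2 holds the higher one, with compound 1 as its nearest neighbour.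

Compound 3, `CC1=C(SCC(C)O)C(=O)c2ccccc2C1=O`, has not yet been measured. Against compound 2 it differs in one place: 1-hydroxyethyl in place of 5-hydroxypentyl on a saturated chain carbon bound to a sulfur. Within the data shown here, of the measured steps only the one from compound 1 to compound 2 bears on this change, since it too alters the hydroxy-bearing chain on the sulfur, and that step was within the scatter. Compound 3 is therefore expected to show a step of a 1.5-fold lower number from compound 2 to compound 3 (0.19 log units; within the scatter) that does not exceed the scatter. On that basis compound 3 is estimated at 6000 nM, within a range from 2500 nM to 14000 nM.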

Compound 3, half-maximal inhibitory concentration: 4610 nM
Beside the measured number, compound 3's estimate is 1.3-fold (0.11 log units) above it; measured number inside the range.
By their numbers in this assay, from the lowest: compounds 3, 1 and 2 (each within the scatter of the next).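

Replacing 5-hydroxypentyl with 1-hydroxyethyl on the saturated chain carbon bound to the sulfur gives a 2.0-fold lower number from compound 2 to compound 3 (0.30 log units; within the scatter) in this assay, so this larger cut in the chain, from 6 heavy atoms to 3 in the group as named, cannot be told apart from no change in this read-out. The other new comparison concerns the place of the hydroxy group on a two-carbon chain, with 1-hydroxyethyl in place of 2-hydroxyethyl, and gives a 1.1-fold lower number from compound 1 to compound 3 (0.05 log units; within the scatter), so within these three compounds neither the change in chain length nor this shift of the hydroxy group separates one compound from another. Nothing at hand gives a reason for this flat picture.

The three compounds all carry a hydroxy group on the chain at the sulfur, so they leave open whether an amine or a carboxylic acid in its place would move the number beyond the scatter. They also leave open whether a plain alkyl chain without the hydroxy group, or a chain longer than 6-hydroxyhexyl, would do so.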